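The compounds below may be only part of what the source reports. "The series", "measured", "known", "first", "only" and "open" are said of these compounds alone.

In a physicochemical assay for lipophilicity, read by HPLC, at pH 7.4 (on this read-out lower numbers stand for lower lipophilicity and higher numbers for higher lipophilicity), compound 1 (`Cc1ccccc1C(=O)Nc1cccc(F)n1`) gives 3, compound 2 (`Cc1c(C(=O)Nc2ccccn2)ccc(F)c1F`) gives 2.8 and compound 3 (`Cc1c(F)cccc1C(=O)Nc1ccccn1`) gives 2.6. Compound 3 thus lies within the scatter of compound 2 and beyond the scatter on the lower side of compound 1. Compound 4 (`Cc1ccnc(NC(=O)c2cccc(F)c2C)c1`) carries methyl in place of hydrogen on an aromatic carbon, methyl in place of hydrogen on an aromatic carbon, opposite the ring nitrogen. Among the measured compounds shown here, the only measured step, a number 0.20 log units lower from compound 2 to compound 3 (within the scatter), is hydrogen in place of fluoro, and no measured step introduces a methyl, so the data offer no direct guide to size. The step expected in this assay is a number 0.40 log units higher from compound 3 to compound 4 (beyond the scatter), an upward estimate without measured support. For compound 4 the estimated value is 3, with an expected range from 2.7 to 3.3.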

Compound 4, distribution coefficient: 3.5
Beside the measured number, compound 4's estimate is 0.50 log units below it, outside the stated range (above it).
By their numbers in this assay, from the lowest: compounds 3, 2 and 1 (each within the scatter of the next, the first and the last beyond it); then compound 4.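

In this assay, methyl in place of hydrogen on an aromatic carbon, opposite the ring nitrogen, gives a number 0.90 log units higher from compound 3 to compound 4 (beyond the scatter). Among the compounds shown here, this is the first step at this position and the first to introduce a methyl, and unlike a number 0.20 log units lower from compound 2 to compound 3 (within the scatter), it lies beyond the scatter. Nothing at hand accounts for the size of this step.

Open, on these data alone, is how an ethyl group or an amine at this position would compare with methyl. Also open, as far as these compounds go, is whether methyl on other aromatic carbons of this ring gives a step of similar size.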